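Fluoromethyl to trifluoromethyl in the amide series

This account rests on a few compounds, and the source may have more. Where it says the series, first, only, none or still open, it means among the compounds named here.

Measured so far:
- compound 1, `CC1(CF)C=C(/C(S)=N\CCC#N)c2cc([N+](=O)[O-])ccc2O1`: 59.6%
- compound 2, `CC1(C(F)(F)F)C=C(/C(S)=N\CCC#N)c2cc([N+](=O)[O-])ccc2O1`: 69.7%
- compound 3, `CC1(CF)C=C(C(=O)NCCC#N)c2cc([N+](=O)[O-])ccc2O1`: 71%

All three were run in a functional assay on the whole organism (aorta) with Rattus norvegicus as the target; on this read-out higher numbers stand for larger maximal responses and lower numbers for smaller maximal responses. Compound 1 and compound 2 share one core and differ by trifluoromethyl in place of fluoromethyl on a saturated ring carbon; this gave a number 10.1 percentage points higher from compound 1 to compound 2 (beyond the scatter). Compound 3 differs from compound 1 by a group of 7 heavy atoms (4 carbon, 2 nitrogen, 1 oxygen; no ring) in place of a group of 7 heavy atoms (4 carbon, 2 nitrogen, 1 sulfur; no ring), on a double-bonded ring carbon, which gave a number 11.4 percentage points higher from compound 1 to compound 3 (beyond the scatter). The values of compound 2 and compound 3 lie within the scatter of each other, so no order between them is claimed.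

Not yet measured is compound 4, `CC1(C(F)(F)F)C=C(C(=O)NCCC#N)c2cc([N+](=O)[O-])ccc2O1`. It differs from compound 3 by trifluoromethyl in place of fluoromethyl on a saturated ring carbon. This is the same kind of change as the one from compound 1 to compound 2, and it occurs twice among the compounds shown. Around the place the descriptions differ only in that the ring atom two ring bonds away bears a (2-cyanoethyl)carbamoyl group in compound 3 and compound 4, where in compound 1 and compound 2 it bears a group of 7 heavy atoms of the other kind.

With a single earlier instance to rest on, the step from compound 3 to compound 4 in this assay is expected to be a number 8 percentage points higher from compound 3 to compound 4 (within the scatter), of about the size of the step seen earlier, because that earlier change gave a number 10.1 percentage points higher from compound 1 to compound 2 (beyond the scatter). For the measured compounds named here, compound 4 is therefore expected to reach about 79%, between 66% and 92%; the uncertainty is wide, as the change has been seen on only one other core.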

Compound 4, intrinsic activity: the largest response reached, in percent of the reference agonist's: 70.6%
Compound 4: the middle estimate sits 8.4 percentage points above what was measured, within the range that was stated.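

In this assay, trifluoromethyl in place of fluoromethyl on the saturated ring carbon gives a number 0.4 percentage points lower from compound 3 to compound 4 (within the scatter), and the two instances of this change cannot be told apart across the two cores: the same change on two cores in this assay, a number 10.1 percentage points higher (beyond the scatter) from compound 1 to compound 2 and a number 0.4 percentage points lower (within the scatter) from compound 3 to compound 4, 10.5 percentage points apart, within the scatter of two such steps. The exchange of the group of 7 heavy atoms, read on the trifluoromethyl compounds, gives a number 0.9 percentage points higher from compound 2 to compound 4 (within the scatter), and it too cannot be told apart from its earlier instance on the fluoromethyl compounds: the same change on two cores in this assay, a number 11.4 percentage points higher (beyond the scatter) from compound 1 to compound 3 and a number 0.9 percentage points higher (within the scatter) from compound 2 to compound 4, 10.5 percentage points apart, within the scatter of two such steps. With one step beyond the scatter and its counterpart within it, but the gap between them within the scatter of two such steps, two instances per change show neither that a change carries over at the same size nor that its size depends on the core.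

The compounds shown leave open how a plain methyl or ethyl group on the saturated ring carbon would compare with fluoromethyl and trifluoromethyl on either core. Also open, on these data alone, is whether either change would read the same with a longer chain than 2-cyanoethyl, or with a carboxylic acid or an amine in place of the nitrile.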